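The source may hold more compounds than are shown below. What is called first, only, known or untested is meant among the compounds shown, and "the series" means these compounds.

In a functional assay on the whole organism for inhibition, with Scenedesmus acutus as the target (on this read-out higher numbers stand for weaker inhibition and lower numbers for stronger inhibition), three esters built on one shared core have been measured. Compound 1 `COC(=O)c1cc(N2C(=O)C3=C(CCCC3)C2=O)ccc1Cl` gives 1780 nM, compound 2 `CCCOC(=O)c1cc(N2C(=O)C3=C(CCCC3)C2=O)ccc1Cl` gives 1120 nM, and compound 3 `CC(C)(C)OC(=O)c1cc(N2C(=O)C3=C(CCCC3)C2=O)ccc1Cl` gives 81300 nM. Compound 3 therefore has the highest number of the three, and it is the weakest inhibitor in the set. The next compound is compound 4 `CCCCCCCCOC(=O)c1cc(N2C(=O)C3=C(CCCC3)C2=O)ccc1Cl`, with octyl in place of tert-butyl on an oxygen next to a carbonyl group. For the measured compounds named here, three measured steps bear on this change. The large steps of a 46-fold higher number from compound 1 to compound 3 (1.66 log units; beyond the scatter) and a 73-fold higher number from compound 2 to compound 3 (1.86 log units; beyond the scatter) both bring in tert-butyl, which compound 4 gives up. The step of a 1.6-fold lower number from compound 1 to compound 2 (0.20 log units; within the scatter) lies within the scatter, so the change from methyl to propyl shows no clear effect. Going by the values given here, no measured compound carries a chain as long as octyl, so the extrapolation is uncertain. A large fall in the number is expected, with an estimated 41-fold lower number from compound 3 to compound 4 (1.61 log units; beyond the scatter). For compound 4 the estimated value is 2000 nM, with an expected range from 500 nM to 15000 nM.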

Compound 4, half-maximal inhibitory concentration: > 100000 nM
Compound 4: a limit, no number; the forecaster's own chance of this, stated with the estimate: 10%; at least 50-fold (1.69 log units) between middle value and limit.
By their numbers in this assay, from the lowest: compounds 2 and 1 (each within the scatter of the next); then compound 3. At a limit, above all of these: compound 4.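

In this assay compound 4 gives > 100000 nM, which is a limit of the assay and not a number. On an oxygen next to a carbonyl group, octyl therefore does not hold the level seen with the shorter straight chains, as the steps show: an at least 89-fold higher number from compound 2 to compound 4 (1.95 log units; beyond the scatter) and an at least 56-fold higher number from compound 1 to compound 4 (1.74 log units; beyond the scatter); the series thus shows that a straight chain here is not tolerated at every length, which methyl and propyl alone could not reveal. Against tert-butyl the step is an at least 1.2-fold higher number from compound 3 to compound 4 (0.08 log units; that floor lies within the scatter), and with that floor inside the scatter the order of octyl and tert-butyl stays unsettled.

Where between propyl and octyl the number starts to climb remains open, and a butyl or hexyl ester could locate it. From the compounds shown here alone, whether the ester itself is needed remains open too, a question a carboxylic acid or an amide at this place would address.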